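The source may hold more compounds than are shown below. What is called first, only, known or untested is meant among the compounds shown, and "the series" means these compounds.

Three compounds share one core and differ only in the aromatic group on the carbon with a double bond to nitrogen. In a functional assay on MCF7 cells (Homo sapiens) for antiproliferative activity, read by MTT assay, with a stated time of 72 h (on this read-out lower numbers stand for stronger inhibition and higher numbers for weaker inhibition), compound 1 `O=C(N/N=C/c1ccccn1)c1cccc(S(=O)(=O)N2CCOCC2)c1` reaches only the limit of the assay, > 100000 nM. Among the measured compounds shown here, compound 2 `O=C(N/N=C/c1ccccc1O)c1cccc(S(=O)(=O)N2CCOCC2)c1` gives 29100 nM, the highest of the two numbers measured so far, and compound 3 `CCN(CC)c1ccc(/C=N/NC(=O)c2cccc(S(=O)(=O)N3CCOCC3)c2)c(O)c1` gives 3520 nM. The measured steps were an at least 3.4-fold lower number from compound 1 to compound 2 (0.53 log units; beyond the scatter) and an 8.3-fold lower number from compound 2 to compound 3 (0.92 log units; beyond the scatter). Compound 4 `CCOc1cccc(/C=N/NC(=O)c2cccc(S(=O)(=O)N3CCOCC3)c2)c1O` carries ethoxy in place of hydrogen on an aromatic carbon. The step from compound 2 to compound 3 also added a group to that ring and gave a modest lowering. Here a smaller group of a different kind enters, so the step to compound 4 is expected to be a 1.9-fold lower number from compound 2 to compound 4 (0.29 log units; within the scatter). Compound 4 is therefore estimated at 15000 nM, between 5000 nM and 50000 nM.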

Compound 4, half-maximal inhibitory concentration: 19300 nM
Estimate against measurement, compound 4: 1.3-fold (0.11 log units) below; the measured number falls inside the stated range.
By their numbers in this assay, from the lowest: compound 3; then compounds 4 and 2 (each within the scatter of the next). At a limit, above all of these: compound 1.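

Ethoxy on this aromatic carbon, ortho to a hydroxy group, gives a 1.5-fold lower number from compound 2 to compound 4 (0.18 log units; within the scatter), so adding a group to this ring does not always bring a step beyond the scatter, as the diethylamino group of compound 3 did. Taking 3-ethoxy-2-hydroxyphenyl in place of pyridin-2-yl gives an at least 5.1-fold lower number from compound 1 to compound 4 (0.71 log units; beyond the scatter), which sets only a minimum size for the step. Compound 1 stands at a limit of the assay, so its true value stays unknown: the limit of > 100000 nM in this assay, at which 1 of the 4 values shown sits.

From the compounds shown here alone, whether a longer chain such as butoxy would behave like ethoxy on this carbon remains open. So does the effect of an amine or a carboxylic acid placed there.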